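Chloro for fluoro on the aryl piperazine of compound 2

A few compounds are considered here, and "the series" means these few. Any claim that something is new, unique, unknown or untested is made for them only; others in the source may bear on it.

Compounds measured so far:
compound 1, `Nc1scc(CN2CCN(c3cccc(C(F)(F)F)c3)CC2)c1C(=O)c1ccc(Cl)cc1`, 0%
compound 2, `Nc1scc(CN2CCN(c3ccc(F)c(F)c3)CC2)c1C(=O)c1ccc(Cl)cc1`, 0%

In an assay on CHO cells for displacement of a labelled ligand from adenosine receptor A1 (Homo sapiens), read by scintillation counting, with a stated time of 120 min, tested at 10 uM (a higher number here means more inhibition at the concentration tested (going by the name of the read-out), a lower number less inhibition), compound 1 gives 0%. Compound 2 sits level with it: in this assay compound 2 gives 0%, and the step of no change at the digits printed from compound 1 to compound 2 (within the scatter) stays within the scatter, so the change from 3-(trifluoromethyl)phenyl to 3,4-difluorophenyl on the amine nitrogen in the ring left the read-out where it was.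

Compound 3, `Nc1scc(CN2CCN(c3ccc(F)c(Cl)c3)CC2)c1C(=O)c1ccc(Cl)cc1`, has not yet been measured in this assay. It differs from compound 2 by chloro in place of fluoro on an aromatic carbon, on an aromatic carbon ortho to a fluoro group and meta to a large group. For the measured compounds named here, the only step that bears on it, no change at the digits printed from compound 1 to compound 2 (within the scatter), was flat even for a larger exchange on the same ring, so no step beyond the scatter is expected for compound 3: the expected step is a number 2 percentage points higher from compound 2 to compound 3 (within the scatter). Compound 3 is therefore estimated at 2%, in the range 0% to 15%.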

Compound 3, a percentage reported as inhibition, at one concentration (the size of the read-out at that concentration, not a potency): 0%
Beside the measured number, compound 3's estimate is 2 percentage points above it; the range from low to high includes it.
By their numbers in this assay, from the lowest: compounds 1, 2 and 3 (each within the scatter of the next).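

In this assay, exchanging fluoro for chloro on an aromatic carbon, ortho to a fluoro group and meta to a large group, gives no change at the digits printed from compound 2 to compound 3 (within the scatter), so a change of one halogen at this place leaves the read-out untouched. Replacing 3-(trifluoromethyl)phenyl with 3-chloro-4-fluorophenyl gives no change at the digits printed from compound 1 to compound 3 (within the scatter), which makes three differently substituted aryl groups on the amine nitrogen that read alike. With compound 3 at 0%, none of these exchanges yields any measurable inhibition at the concentration tested, and nothing available explains this result.

On these data alone, whether a hydroxyl, an amine or a carboxylic acid on this aryl ring would produce any inhibition remains open. So does whether replacing the 4-chlorobenzoyl group or the free amine on the shared core would change the reading.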